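Methyl for methoxy: compound 3 to compound 4

The compounds below may be only part of what the source reports. "The series", "measured", "known", "first", "only" and "open" are said of these compounds alone.

Measured in a functional assay on KYSE-450 cells (Homo sapiens) for inhibition, read by MTT assay, with a stated time of 48 h; a lower number here means a stronger inhibitor, a higher number a weaker inhibitor:
Compound 1 `COc1cc(NCc2ccc(Br)cc2)cc(OC)c1OC` gives > 80000 nM (a limit of the assay, not a number)
Compound 2 `COc1cc(NCc2cccc(O)c2)cc(OC)c1OC` gives 71300 nM
Compound 3 `COc1ccc(CNc2cc(OC)c(OC)c(OC)c2)cc1` gives 4890 nM

Compound 3 has the lowest number of the set, beyond the scatter from compound 2 and from the limit of compound 1. Compound 4 `COc1cc(NCc2ccc(C)cc2)cc(OC)c1OC` carries methyl in place of methoxy on an aromatic carbon, para to a large group: methyl in place of methoxy on an aromatic carbon.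

The closest measured evidence is a change of group at that same place, methoxy in place of bromo on an aromatic carbon: an at least 16-fold lower number from compound 1 to compound 3 (1.21 log units; beyond the scatter). That size is only a floor, as the step rests on (the limit of > 80000 nM in this assay, at which 1 of the 3 values shown sits). The other step, an at least 1.1-fold lower number from compound 1 to compound 2 (0.05 log units; that floor lies within the scatter), alters both the group and its place and bears on the question less directly. Among the compounds with values here, no methyl compound has been measured, so the size of the new step remains open. Compound 4 gives up the methoxy found in compound 3, so a move to a higher number in this assay is expected, probably smaller than the bromo step. The expected change is a 4.1-fold higher number from compound 3 to compound 4 (0.61 log units; beyond the scatter). Compound 4 is estimated at 20000 nM, with an expected range from 5000 nM to 80000 nM.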

Compound 4, half-maximal inhibitory concentration: > 80000 nM
Compound 4: a limit, no number; the forecaster's own chance of this, stated with the estimate: 15%; middle value at least 4.0-fold (0.60 log units) from the limit.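

In this assay compound 4 gives (> 80000 nM), which is a limit of the assay and not a number. At this place, on an aromatic carbon para to a large group, methyl does not keep the low number of compound 3 (an at least 16-fold higher number from compound 3 to compound 4 (1.21 log units; beyond the scatter)), so the loss seen with bromo now appears with a second group and is not tied to bromo alone. The step from the 3-hydroxyphenyl compound (an at least 1.1-fold higher number from compound 2 to compound 4 (0.05 log units; that floor lies within the scatter)) has a floor within the scatter, and the step between compound 1 and compound 4 cannot be read, since both values are limits: the limit of > 80000 nM in this assay, at which 2 of the 4 values shown sit.

Of the groups shown at this place, only methoxy gives a number well inside the range of the assay, and whether ethoxy, an amine or fluoro would do the same remains open. From the compounds shown here alone, the step to compound 4 stands as a floor only, so its true size is also open, as is how far compound 4 and compound 1 each lie from that limit.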